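This account rests on a few compounds, and the source may have more. Where it says the series, first, only, none or still open, it means among the compounds named here.

Of the compounds shown here, three in this set have been measured and one has not. Compound 1 `C[Se]/C(=N\C(=O)c1cc2ccccc2s1)NC(=O)c1cc2ccccc2s1`, compound 2 `C[Se]/C(=N\C(=O)c1cnc2ccccc2c1)NC(=O)c1cnc2ccccc2c1` and compound 3 `O=C(/N=C(/NC(=O)c1ccno1)[Se]Cc1ccccc1)c1ccno1` were each tested in a functional assay on HepG2 cells (Homo sapiens) for cytotoxicity, read by MTT assay, with a stated time of 72 h; a higher number here means a weaker inhibitor of growth, a lower number a stronger inhibitor of growth. In this assay compound 1 gives 9590 nM, the highest of the three numbers. Compound 3 gives 9120 nM, a number within the scatter of that of compound 1, so the two cannot be told apart. Compound 2 gives 4160 nM, a lower number lying beyond the scatter relative to compound 1.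

Compound 4 `O=C(/N=C(/NC(=O)c1cc2ccccc2s1)[Se]Cc1ccccc1)c1cc2ccccc2s1` awaits measurement. It differs from compound 1 in one place: phenyl in place of hydrogen on a saturated chain carbon bound to a selenium atom. Going by the values given here, no measured pair isolates this change, so its effect is not known from the data. The nearest guide is compound 3, which carries the benzyl group on a different core and gives 9120 nM, close to the number for compound 1. Compound 4 is therefore expected to remain near its parent, with an estimated step of a 1.2-fold lower number from compound 1 to compound 4 (0.08 log units; within the scatter) within the scatter. Compound 4 is estimated at 8000 nM, with a range from 3000 nM to 20000 nM.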

Compound 4, concentration for 50% growth inhibition: 21000 nM
Beside the measured number, compound 4's estimate is 2.6-fold (0.42 log units) below it, outside the stated range (above it).
By their numbers in this assay, from the lowest: compound 2; then compounds 3 and 1 (each within the scatter of the next); then compound 4.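

In this assay phenyl in place of hydrogen on a saturated chain carbon bound to a selenium atom gives a 2.2-fold higher number from compound 1 to compound 4 (0.34 log units; beyond the scatter) and so modestly weakens growth inhibition on the core of compound 1. Going by these compounds alone, this is the first pair to isolate the change, and it shows that this position is not indifferent to what it carries: going from methyl to benzyl moves the number beyond the scatter, towards weaker inhibition. No measurement shown here accounts for this shift.

Within the data shown here, whether the same step holds on the cores of compound 2 and compound 3 stays open, as each appears with only one group at this place. Also open, from the compounds shown here alone, is how an ethyl group, a longer chain, or a chain ending in an amine or a carboxylic acid would read on the selenium atom.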